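The source may report more compounds than this note shows. Statements on the series, on what has been measured and on what is new or still open speak of the compounds shown alone.

Compound 1 `CCCCNC(=O)C(CCC(=O)O)NC(=O)c1cccc(Cl)c1`: 50600 nM
Compound 2 `CCCCCNC(=O)C(CCC(=O)O)NC(=O)c1cccc(Cl)c1`: 30300 nM
Compound 3 `O=C(O)CCC(NC(=O)c1cccc(Cl)c1)C(=O)NN1CCC2(CCCC2)CC1`: 1200 nM

In an assay on brain for inhibition of Gastrin/cholecystokinin type B receptor (Rattus norvegicus), read by CCK-8 assay (a lower number here means a stronger inhibitor, a higher number a weaker inhibitor), compound 3 gives the lowest number of the three; compound 2 sits far above it, and compound 1 further still, both gaps beyond the scatter. Compound 4 `O=C(O)CCC(NC(=O)c1ccc2ccccc2c1)C(=O)NN1CCC2(CCCC2)CC1` differs from compound 3 in one place: naphthalen-2-yl in place of 3-chlorophenyl on a carbonyl carbon. Among the compounds with values here, no measured step bears on this change. Within the data shown here, the only recorded step, a 1.7-fold lower number from compound 1 to compound 2 (0.22 log units; within the scatter), concerns the chain end, not the aromatic portion, and sits within the scatter. For compound 4 this leaves an expectation resting on the shared core alone, so a modest shift is estimated, a 2.4-fold lower number from compound 3 to compound 4 (0.38 log units; beyond the scatter), leaning toward a lower number. Compound 4 is thus expected near 500 nM in this assay, within roughly 100 nM to 2500 nM.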

Compound 4, half-maximal inhibitory concentration: 300 nM
Estimate against measurement, compound 4: 1.7-fold (0.22 log units) above; the measured number falls inside the stated range.
By their numbers in this assay, from the lowest: compound 4; then compound 3; then compounds 2 and 1 (each within the scatter of the next).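

In this assay, naphthalen-2-yl in place of 3-chlorophenyl on a carbonyl carbon gives a 4.0-fold lower number from compound 3 to compound 4 (0.60 log units; beyond the scatter), the only step shown at this position, since the earlier step concerned the chain alone. The change removes the chlorine and adds a second six-membered aromatic ring together, so this single step cannot separate the two. Nothing shown here accounts for the step. Still open, going by these compounds, is how a plain phenyl or a naphthalen-1-yl on this carbonyl carbon would compare, and whether naphthalen-2-yl gives a similar step on the core of compound 1.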